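The compounds below may be only part of what the source reports. "The series", "measured", "known", "first", "only" and "open" are said of these compounds alone.

Values in an ADME assay on HEK293 cells (Homo sapiens) for cytotoxicity, read by MTT assay, with a stated time of 48 h; on this read-out higher numbers stand for weaker inhibition and lower numbers for stronger inhibition:

compound 1 `Cc1cc(NC(=O)c2ccc(Cl)c([N+](=O)[O-])c2)ccc1NS(C)(=O)=O` — 73100 nM
compound 2 `CCS(=O)(=O)Nc1ccc(NC(=O)c2ccc(Cl)c([N+](=O)[O-])c2)cc1C` — 144000 nM
compound 3 `Cc1cc(NC(=O)c2ccc(Cl)c([N+](=O)[O-])c2)ccc1NS(=O)(=O)C(F)(F)F` — a limit, > 250000 nM

Compound 2 holds the highest of the two numbers in this assay; compound 1 is nearest, and the step of a 2.0-fold higher number from compound 1 to compound 2 (0.29 log units; within the scatter) shows the two cannot be told apart. Compound 3 gives only the limit of > 250000 nM in this assay, at which 1 of the 3 values shown sits, and no number of its own.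

All three measured steps sit on the sulfonyl sulfur: a 2.0-fold higher number from compound 1 to compound 2 (0.29 log units; within the scatter), an at least 3.4-fold higher number from compound 1 to compound 3 (0.53 log units; beyond the scatter) and an at least 1.7-fold higher number from compound 2 to compound 3 (0.23 log units; that floor lies within the scatter). The change now followed is elsewhere. Compound 4 `CCS(=O)(=O)Nc1ccc(NC(=O)c2ccc(Cl)c([N+](=O)[O-])c2)cc1Cl` differs from compound 2 by chloro in place of methyl on an aromatic carbon. Within the data shown here, no measured step touches that aromatic carbon, so none of the three bears directly on it; the sulfonyl steps only show that small changes around the sulfonamide moved the read-out little or not beyond the scatter. In this assay a step of a 1.0-fold lower number from compound 2 to compound 4 (0.01 log units; within the scatter) is therefore expected, which is none beyond the scatter. Compound 4 is expected to give 140000 nM, with a range of 55000 nM to 250000 nM.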

Compound 4, half-maximal inhibitory concentration: 63800 nM
The estimate for compound 4 lay 2.2-fold (0.34 log units) above the measured number; the measured number falls inside the stated range.
By their numbers in this assay, from the lowest: compounds 4, 1 and 2 (each within the scatter of the next, the first and the last beyond it). At a limit, above all of these: compound 3.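

In this assay, the aromatic carbon ortho to the (ethylsulfonyl)amino group proves responsive to substitution: a 2.3-fold lower number from compound 2 to compound 4 (0.35 log units; beyond the scatter). This is the only step shown away from the sulfonyl sulfur, and it is modest but clears the scatter, which the addition of one carbon to the sulfonyl chain does not: a 2.0-fold higher number from compound 1 to compound 2 (0.29 log units; within the scatter). The data shown offer no measured property that accounts for the exchange of methyl for chloro at this carbon.

Compound 4 is the only chloro compound shown, so it remains open whether the same exchange would carry over with methyl or trifluoromethyl on the sulfonyl sulfur. As far as these compounds go, how hydrogen, fluoro or methoxy at this same aromatic carbon would read in this assay also remains open.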